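The source may report more compounds than this note shows. Statements on the series, on what has been measured and on what is new or still open speak of the compounds shown alone.

Measured in a functional assay on HL-60 cells (Homo sapiens) for cytotoxicity, read by MTT assay, with a stated time of 24 h; on this read-out higher numbers stand for weaker inhibition and lower numbers for stronger inhibition:
- compound 1 `CC(=O)Oc1c(Br)cc(Br)cc1Oc1ccc(Br)cc1Br`: 29.9 ug/mL
- compound 2 `COc1ccccc1N1CCN(CCCCCOc2c(Br)cc(Br)cc2Oc2ccc(Br)cc2Br)CC1`: 32.2 ug/mL
- compound 3 `BrCCOc1c(Br)cc(Br)cc1Oc1ccc(Br)cc1Br`: 26.2 ug/mL

In this assay compound 2 gives 32.2 ug/mL, a value within the scatter of those of compound 1 and compound 3. The three compounds therefore cannot be told apart on these numbers.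

The next compound, compound 4 `Brc1ccc(Oc2cc(Br)cc(Br)c2OCCCCCN2CCN(C/C=C/c3ccccc3)CC2)c(Br)c1`, has not yet been measured. It differs from compound 2 as follows: 3-phenylprop-2-en-1-yl in place of 2-methoxyphenyl on an amine nitrogen in a ring. In words, 3-phenylprop-2-en-1-yl stands in place of 2-methoxyphenyl on an amine nitrogen in a ring.

Within the data shown here, only one measured step is available, a 1.1-fold lower number from compound 1 to compound 3 (0.06 log units; within the scatter), and it lies within the scatter. It concerns a group on an oxygen on an aromatic ring, so it bears on the new change only indirectly. Among the measured compounds shown here, no measured pair tests a change on the amine nitrogen. No step beyond the scatter is therefore expected in this assay.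

The expected step is a 1.2-fold lower number from compound 2 to compound 4 (0.08 log units; within the scatter).

For compound 4 the estimated half-maximal inhibitory concentration is 27 ug/mL, with an expected range of 12 ug/mL to 55 ug/mL.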

Compound 4, half-maximal inhibitory concentration: 47.2 ug/mL
Estimate against measurement, compound 4: 1.7-fold (0.24 log units) below, within the range that was stated.
By their numbers in this assay, from the lowest: compounds 3, 1, 2 and 4 (each within the scatter of the next).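

Among these compounds, this is the first measured pair that tests a change on the amine nitrogen in the ring. In this assay, the exchange of 2-methoxyphenyl for 3-phenylprop-2-en-1-yl gives a 1.5-fold higher number from compound 2 to compound 4 (0.17 log units; within the scatter), so this change does not separate the two compounds, even though the entering group has no hydrogen-bond acceptor and brings a double bond outside aromatic rings. No evidence is available that bears on this result.

The compounds shown leave open whether any other group on this nitrogen, such as benzyl or a chain ending in a carboxylic acid, would give a step beyond the scatter. They also leave open whether a longer chain on the oxygen of the shared core would do so.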